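Swapping a pyrazole for a pyridine: what clearance to expect

The compounds below may be only part of what the source reports. "The series", "measured", "known", "first", "only" and "open" are said of these compounds alone.

Compound 3 `Cn1nccc1-c1cnc(NCc2c(F)ccc3c2CCO3)c2cn[nH]c(=O)c12` gives 14 mL.min-1.g-1 in an ADME assay on microsomes from liver (Homo sapiens) for metabolic stability, read by LC-MS, using NADPH, with stated times of 5 min and 30 min, tested at 1 uM (on this read-out lower numbers stand for slow clearance and higher numbers for fast clearance), the lower of the two numbers shown, although its gap to compound 1 is within the scatter. Compound 1 `Cn1cc(-c2cnc(NCc3c(F)ccc4c3CCO4)c3cn[nH]c(=O)c23)cn1` gives 21 mL.min-1.g-1, and a 1.5-fold lower number from compound 1 to compound 3 (0.18 log units; within the scatter). Compound 2 `CNC(=O)c1cc(-c2cnc(NCc3c(F)ccc4c3CCO4)c3cn[nH]c(=O)c23)n(C)n1` sits at a limit of the assay, < 3 mL.min-1.g-1. Compound 4 `Cc1nc(CO)ccc1-c1cnc(NCc2c(F)ccc3c2CCO3)c2cn[nH]c(=O)c12` differs from compound 3 by 6-(hydroxymethyl)-2-methylpyridin-3-yl in place of 1-methyl-1H-pyrazol-5-yl on an aromatic carbon. Within the data shown here, no measured step makes exactly this change. The closest guide is an at least 4.6-fold higher number from compound 2 to compound 3 (0.66 log units; beyond the scatter), which shows that adding a polar group to the ring at this position can cut clearance clearly, whereas a 1.5-fold lower number from compound 1 to compound 3 (0.18 log units; within the scatter) shows a small rearrangement of the pyrazole changes little. The incoming ring brings one hydrogen-bond donor, so a modest downward step is expected, a 1.6-fold lower number from compound 3 to compound 4 (0.19 log units; within the scatter). Compound 4 is estimated at 9 mL.min-1.g-1, between 3 mL.min-1.g-1 and 25 mL.min-1.g-1.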

Compound 4, intrinsic clearance in microsomes: 11 mL.min-1.g-1
Compound 4: middle estimate off by 1.2-fold (0.09 log units), on the low side; low and high end bracket the measured number.
By their numbers in this assay, from the lowest: compounds 4, 3 and 1 (each within the scatter of the next). At a limit, below all of these: compound 2.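

In this assay, putting a six-membered ring at this position in place of a five-membered one changes little, with a 1.3-fold lower number from compound 3 to compound 4 (0.10 log units; within the scatter) and a 1.9-fold lower number from compound 1 to compound 4 (0.28 log units; within the scatter) as the two steps. The position therefore takes 6-(hydroxymethyl)-2-methylpyridin-3-yl, with its hydrogen-bond donor, and stays level with compound 1 and compound 3, whereas the comparison with compound 2 gives an at least 3.6-fold higher number from compound 2 to compound 4 (0.56 log units; beyond the scatter) as the step. Compound 2 carries a limit, not a number: the limit of < 3 mL.min-1.g-1 in this assay, at which 1 of the 4 values shown sits.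

From the compounds shown here alone, the separate shares of the ring, the methyl and the hydroxymethyl stay open. So does the effect of an amine or a carboxylic acid in place of that hydroxymethyl.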